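A few compounds are considered here, and "the series" means these few. Any claim that something is new, unique, unknown or untested is made for them only; others in the source may bear on it.

Measured compounds in a functional assay on cells (T-cell, Mus musculus, strain BALB/c) for inhibition, read by MTT assay, with stated times of 24 h and 72 h; on this read-out lower numbers stand for stronger inhibition and higher numbers for weaker inhibition:
compound 1 `COc1cc(-c2nnc(SCc3ccc([N+](=O)[O-])cc3)o2)ccc1O` — 14200 nM
compound 2 `COc1cc(-c2nnc(SCc3ccccc3)o2)ccc1O` — 1250 nM

Among the compounds with values here, compound 1 gives the highest number of the two, weaker than compound 2 by the step of an 11-fold lower number from compound 1 to compound 2 (1.06 log units; beyond the scatter), the only change so far being hydrogen in place of nitro on an aromatic carbon. Compound 3 `COc1cc(-c2nnc(SCc3ccc([N+](=O)[O-])cc3)o2)ccc1OCc1ccc([N+](=O)[O-])cc1` is not yet measured. Relative to compound 1 the change is 4-nitrobenzyl in place of hydrogen on an oxygen on an aromatic ring; the nitrobenzylthio side of the core is unchanged. Within the data shown here, no measured step touches the phenolic oxygen, so the step from compound 1 to compound 2, large as it is, does not bear on this change, and the direction of the new step has no precedent. Compound 1 already sits at the weak end of this assay. The working expectation for compound 3 is a number close to that of compound 1, the step of a 1.4-fold higher number from compound 1 to compound 3 (0.15 log units; within the scatter) being the estimate, and the estimated value is 20000 nM with a range of 6000 nM to 70000 nM.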

Compound 3, half-maximal inhibitory concentration: 7600 nM
Compound 3: the middle estimate sits 2.6-fold (0.42 log units) above what was measured; low and high end bracket the measured number.
By their numbers in this assay, from the lowest: compound 2; then compounds 3 and 1 (each within the scatter of the next).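

In this assay, within the data shown here, putting 4-nitrobenzyl in place of hydrogen on the oxygen on the aromatic ring gives the first reading at this position (a 1.9-fold lower number from compound 1 to compound 3 (0.27 log units; within the scatter)). With the nitrobenzylthio side in place, the read-out therefore does not separate hydroxy from (4-nitrobenzyl)oxy, even though the change adds a whole aromatic ring to the molecule. Nothing on hand offers an explanation for this result.

From the compounds shown here alone, it remains open whether the same change would also leave the number undisturbed on compound 2 (1250 nM), which lacks the nitro group on the sulfur side. A methyl group, an unsubstituted benzyl or a chain ending in a carboxylic acid or an amine on the same oxygen would show how far this tolerance extends.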